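The source may hold more compounds than are shown below. What is called first, only, known or untested is meant among the compounds shown, and "the series" means these compounds.

Compound 1 `CC1=CC[C@@H]([C@@](C)(O)CCCC(C)(C)NC(=S)NN)CC1` is the parent of this small set; in a functional assay on MCF7 cells (Homo sapiens) for cytotoxicity, read by sulforhodamine B assay (on this read-out higher numbers stand for lower toxicity in this test and lower numbers for higher toxicity in this test), compound 1 gives only the limit > 100000 nM. Compound 2 `CC1=CC[C@@H]([C@@](C)(O)CCCC(C)(C)NC(=S)N/N=C\c2ccccc2)CC1` carries a group of 8 heavy atoms on the amide-type nitrogen, and in this assay compound 2 gives 60400 nM. Compound 3 `CC1=CC[C@@H]([C@@](C)(O)CCCC(C)(C)NC(=S)N/N=C\c2ccccc2Cl)CC1` adds chloro on an aromatic carbon, and in this assay compound 3 gives only the limit > 100000 nM. Compound 3 therefore stands at the limit (the limit of > 100000 nM in this assay, at which 2 of the 3 values shown sit). Compound 4 `CC1=CC[C@@H]([C@@](C)(O)CCCC(C)(C)NC(=S)N/N=C(/C)c2ccccc2)CC1` differs from compound 3 by a group of 9 heavy atoms (8 carbon, 1 nitrogen; one six-membered aromatic ring of carbon only) in place of a group of 9 heavy atoms (7 carbon, 1 nitrogen, 1 chlorine; one six-membered aromatic ring of carbon only), on an amide-type nitrogen. The steps of an at least 1.6-fold lower number from compound 1 to compound 2 (0.21 log units; that floor lies within the scatter) and an at least 1.6-fold higher number from compound 2 to compound 3 (0.21 log units; that floor lies within the scatter) bear on this change, and the step that the two limits leave unreadable from compound 1 to compound 3 cannot be read. With the chloro leaving, an expected at least 1.4-fold lower number from compound 3 to compound 4 (0.15 log units; that floor lies within the scatter) is modest, roughly the floor an at least 1.6-fold higher number from compound 2 to compound 3 (0.21 log units; that floor lies within the scatter) reversed. Compound 4 is thus estimated at 70000 nM, between 25000 nM and 200000 nM.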

Compound 4, concentration lethal to 50% of the cells: > 100000 nM
Compound 4 gave a limit, no number; the forecaster's own chance of this, stated with the estimate: 45%; at least 1.4-fold (0.15 log units) between middle value and limit.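

Compound 4 shows that a group without chlorine on the amide-type nitrogen can also sit at the limit of the assay, which is not a number: the limit of > 100000 nM in this assay, at which 3 of the 4 values shown sit. The change to the group of 9 heavy atoms (8 carbon, 1 nitrogen) gives an at least 1.6-fold higher number from compound 2 to compound 4 (0.21 log units; that floor lies within the scatter), leaving compound 2 as the only one of the set with a number. The steps to compound 4 from compound 1 and compound 3 cannot be read.

As far as these compounds go, how far compound 1, compound 3 and compound 4 lie past the limit stays open. Also open, from the compounds shown here alone, is whether an amine or a carboxylic acid on the aromatic ring would give a number in this assay.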